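This account rests on a few compounds, and the source may have more. Where it says the series, first, only, none or still open, it means among the compounds named here.

Among the compounds with values here, compound 3 `Cc1ccc(C#Cc2ccc3c(n2)CCN(C2CCCC2)C3=O)cc1` stands highest of the three numbers so far in a functional assay on HEK293 cells for positive allosteric modulation of metabotropic glutamate receptor 5 (Homo sapiens), read by FLIPR and calcium flux (a lower number here means that less compound is needed, a higher number that more compound is needed for the effect), giving 4820 nM; compound 1 `O=C1c2ccc(C#Cc3ccccc3)nc2CCN1C1CCCC1` gives 5.9 nM and compound 2 `Cc1cccc(C#Cc2ccc3c(n2)CCN(C2CCCC2)C3=O)c1` gives 7.5 nM. The step to compound 4 `O=C1c2ccc(C#Cc3ccccc3Cl)nc2CCN1C1CCCC1` is 2-chlorophenyl in place of 4-methylphenyl on a triple-bonded carbon. Within the data shown here, two measured steps bear on it: a 640-fold higher number from compound 2 to compound 3 (2.81 log units; beyond the scatter) and an 820-fold higher number from compound 1 to compound 3 (2.91 log units; beyond the scatter), both large, whereas a 1.3-fold higher number from compound 1 to compound 2 (0.10 log units; within the scatter) stayed within the scatter. Among the measured compounds the high number appears only with the 4-methylphenyl, and compound 4 no longer carries that group. Among the measured compounds shown here, the 2-chlorophenyl that enters is not represented anywhere among the measured compounds, so no step tells what the chlorine itself does; its effect is an open question. A large downward step in this assay is expected, a 320-fold lower number from compound 3 to compound 4 (2.51 log units; beyond the scatter), because an 820-fold higher number from compound 1 to compound 3 (2.91 log units; beyond the scatter) shows how much the 4-methylphenyl cost relative to the plain phenyl. Compound 4 is expected to give about 15 nM, with a range of 3 nM to 120 nM.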

Compound 4, half-maximal effective concentration: 393 nM
For compound 4 the middle estimate is 26-fold (1.42 log units) below the measured one; the measured number lies above the stated range.
By their numbers in this assay, from the lowest: compounds 1 and 2 (each within the scatter of the next); then compound 4; then compound 3.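

In this assay, chloro on the phenyl ring is not tolerated as the methyl of compound 2 is: chloro in place of hydrogen gives a 67-fold higher number from compound 1 to compound 4 (1.82 log units; beyond the scatter), whereas methyl in place of hydrogen in compound 2 gave a 1.3-fold higher number from compound 1 to compound 2 (0.10 log units; within the scatter). The high numbers are therefore not confined to the 4-methylphenyl, and the group on the triple-bonded carbon gives a graded response: 2-chlorophenyl gives a 52-fold higher number from compound 2 to compound 4 (1.72 log units; beyond the scatter) against 3-methylphenyl, yet a 12-fold lower number from compound 3 to compound 4 (1.09 log units; beyond the scatter) against 4-methylphenyl. Nothing available accounts for these differences.

Chlorine appears at a single ring place and never at a place shared with methyl, so the effect of the atom cannot be separated from that of its place. From the compounds shown here alone, how a methoxy, a nitrile or an amine on the phenyl ring would behave remains open.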